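Chain variation at the diaryl methine: fluoro for isopropyl

This account rests on a few compounds, and the source may have more. Where it says the series, first, only, none or still open, it means among the compounds named here.

For the measured compounds named here, compound 3 `COc1cc(C(c2ccc(O)c(OC)c2)[C@H](CC(C)C)C(C)C)ccc1O` gives 8200 nM in a functional assay on HeLa cells (Homo sapiens) for cytotoxicity, read by WST assay, with a stated time of 48 h (a lower number here means a stronger inhibitor, a higher number a weaker inhibitor), one of only two numbers in hand; compound 2 `CCCCC[C@H](C(C)C)C(c1ccc(O)c(OC)c1)c1ccc(O)c(OC)c1` at 9200 nM lies within the scatter of it. Compound 1 `COc1cc(C(c2ccc(O)c(OC)c2)[C@@H](C)[C@H](C)CO)ccc1O` reports only the assay limit, > 100000 nM. The steps from it are large: an at least 10-fold lower number from compound 1 to compound 2 (1.03 log units; beyond the scatter) and an at least 12-fold lower number from compound 1 to compound 3 (1.08 log units; beyond the scatter), whereas a 1.1-fold lower number from compound 2 to compound 3 (0.05 log units; within the scatter). Compound 4 `COc1cc(C(c2ccc(O)c(OC)c2)[C@H](CF)C(C)C)ccc1O` carries fluoro in place of isopropyl on a saturated chain carbon, three bonds along the chain from two aromatic carbons. Going by the values given here, the only measured change at this carbon, between compound 2 and compound 3, swapped one alkyl for another and left the number unchanged; the present change shortens the chain further, part way back toward compound 1, so a moderately higher number is expected, a 3.0-fold higher number from compound 3 to compound 4 (0.48 log units; beyond the scatter). Compound 4 is estimated at 25000 nM, within 8000 nM to 80000 nM.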

Compound 4, half-maximal inhibitory concentration: 19000 nM
Beside the measured number, compound 4's estimate is 1.3-fold (0.12 log units) above it, within the range that was stated.
By their numbers in this assay, from the lowest: compounds 3 and 2 (each within the scatter of the next); then compound 4. At a limit, above all of these: compound 1.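

In this assay, for the compounds shown here, fluoro is the first change at this carbon to move the number beyond the scatter: a 2.3-fold higher number from compound 3 to compound 4 (0.36 log units; beyond the scatter), and a 2.1-fold higher number from compound 2 to compound 4 (0.31 log units; beyond the scatter). The value of compound 1, > 100000 nM, is a limit of the assay. Compound 4 nevertheless keeps a measurable number with its shorter chain, with an at least 5.2-fold lower number from compound 1 to compound 4 (0.72 log units; beyond the scatter).

As far as these compounds go, whether the rise goes with the loss of carbons or with the fluorine itself remains open. A plain methyl, a hydroxyl or an amine in place of the fluoro would separate the two.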